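This account rests on a few compounds, and the source may have more. Where it says the series, first, only, none or still open, it means among the compounds named here.

The measured compounds so far:

Compound 1, `Nc1ccccc1NC(=O)c1ccc(CSc2cccc(F)c2)cc1`, gives 76.3% in a functional assay on A-375 cells (Homo sapiens) for inhibition, read by CCK-8 assay, with a stated time of 72 h, tested at 8 uM; on this read-out higher numbers stand for more inhibition of growth at the one concentration tested and lower numbers for less inhibition of growth.
Compound 2, `CCc1ccc(SCc2ccc(C(=O)Nc3ccccc3N)cc2)cc1`, gives 71.1% in this assay.
Compound 3, `Nc1ccccc1NC(=O)c1ccc(CSc2ccc(Cl)cc2)cc1`, gives 48.6% in this assay.

Compound 3 stands lowest of these three numbers. The step of a number 22.5 percentage points lower from compound 2 to compound 3 (beyond the scatter) and the step of a number 27.7 percentage points lower from compound 1 to compound 3 (beyond the scatter) both lie beyond the scatter, so compound 3 is clearly weaker than either neighbour, while the step of a number 5.2 percentage points lower from compound 1 to compound 2 (within the scatter) is within the scatter.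

Compound 4, `Nc1ccccc1NC(=O)c1ccc(CSCCc2ccccc2)cc1`, differs from compound 3 only at the sulfur: phenethyl in place of 4-chlorophenyl on a sulfur. All three measured steps also change the group on that sulfur, and they show that such changes move the numbers by modest amounts at most. None of them involves a phenethyl group, so the direction of the new step is not fixed by the data; the measured range suggests compound 4 will fall somewhere between the value of compound 3 and those of compounds 1 and 2.

For compound 4 the step of a number 11.4 percentage points higher from compound 3 to compound 4 (beyond the scatter) is expected, giving an estimate of 60% in this assay, with a likely range from 40% to 80%.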

Compound 4, percent growth inhibition at one concentration: 69.9%
For compound 4 the middle estimate is 9.9 percentage points below the measured one, within the range that was stated.
By their numbers in this assay, from the lowest: compound 3; then compounds 4, 2 and 1 (each within the scatter of the next).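

In this assay, phenethyl in place of 4-chlorophenyl gives a number 21.3 percentage points higher from compound 3 to compound 4 (beyond the scatter), so the sulfur can carry a group in which a saturated chain carbon, not an aromatic ring carbon, is attached to it. Phenethyl also stays level with the two other groups that give high numbers, with a number 1.2 percentage points lower from compound 2 to compound 4 (within the scatter) and a number 6.4 percentage points lower from compound 1 to compound 4 (within the scatter). Among these four compounds, then, 4-ethylphenyl, 3-fluorophenyl and phenethyl cannot be told apart, and only compound 3 stands apart from the rest.

Nothing available here explains why 4-chlorophenyl gives the lower number or why phenethyl matches the higher ones. From the compounds shown here alone, it also remains open whether an amine, a carboxylic acid or a longer chain ending in a phenyl ring on this sulfur would keep the inhibition at this level.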